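This account rests on a few compounds, and the source may have more. Where it says the series, first, only, none or still open, it means among the compounds named here.

Among the compounds with values here, compound 2 `COc1ccc(CNc2nc3cc(N)cc(N)c3nc2-c2ccccc2)cc1OC` is the weaker of the two compounds measured so far in a functional assay on SK-MEL-5 cells (Homo sapiens) for inhibition, read by sulforhodamine B assay, with a stated time of 48 h (on this read-out lower numbers stand for stronger inhibition of growth and higher numbers for weaker inhibition of growth), where compound 2 gives 27500 nM. Within the data shown here, its only comparator, compound 1 `Nc1cc(N)c2nc(-c3ccccc3)c(NCc3ccc(Cl)c(Cl)c3)nc2c1`, gives 10700 nM in this assay, and the single step between them, a 2.6-fold higher number from compound 1 to compound 2 (0.41 log units; beyond the scatter), came from swapping the two chlorines on the benzylic ring for two methoxy groups. Compound 3 `COc1cc(CNc2nc3cc(N)cc(N)c3nc2-c2ccccc2)cc(OC)c1OC` carries one further change on that same ring: methoxy in place of hydrogen on an aromatic carbon. Among the measured compounds shown here, no measured step covers the addition of a third methoxy group, so the step from compound 1 to compound 2 bears on it only loosely, by showing that oxygen substituents on this ring moved the number modestly upward rather than sharply. Compound 3 is therefore expected to sit close to compound 2, with a step of a 1.2-fold higher number from compound 2 to compound 3 (0.07 log units; within the scatter) at most, and its value in this assay is estimated at 32000 nM within a range of 12000 nM to 85000 nM.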

Compound 3, concentration for total growth inhibition: 7760 nM
Compound 3: middle estimate off by 4.1-fold (0.62 log units), on the high side; measured number below the stated range.
By their numbers in this assay, from the lowest: compounds 3 and 1 (each within the scatter of the next); then compound 2.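

In this assay, adding methoxy in place of hydrogen on an aromatic carbon, ortho to a methoxy group and meta to a large group, gave a 3.5-fold lower number from compound 2 to compound 3 (0.55 log units; beyond the scatter), so this position on the ring responds clearly to substitution. The earlier step, a 2.6-fold higher number from compound 1 to compound 2 (0.41 log units; beyond the scatter), had gone upward when two chlorines gave way to two methoxy groups, so across these compounds, methoxy groups on this ring do not move the number in a single direction. Nothing available here accounts for the downward shift at this position.

As far as these compounds go, whether a hydroxy group, an amine or a fluorine atom at this position would lower the number as methoxy does remains open. Also open, from the compounds shown here alone, is whether a longer chain, such as ethoxy, would keep the lower number seen with compound 3.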